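Amide side-chain variation: compound 2 to compound 3

The compounds below may be only part of what the source reports. "The series", "measured", "known", "first", "only" and "open" are said of these compounds alone.

Compound 1 `O=C(Nc1c(C(O)(C(F)(F)F)C(F)(F)F)ccc2ccccc12)C1CC1` and compound 2 `O=C(Nc1c(C(O)(C(F)(F)F)C(F)(F)F)ccc2ccccc12)C1CCC1` share one core and differ only in the acyl ring. In a functional assay (Sus scrofa) with sulfonylurea receptors; K-ATP channels (Homo sapiens) as the target (on this read-out lower numbers stand for smaller maximal responses and higher numbers for larger maximal responses), compound 1 gives 100% and compound 2 gives 97%; compound 2 thus holds the lowest of the two numbers, though the step of a number 3 percentage points lower from compound 1 to compound 2 (within the scatter) stays within the scatter. Compound 3 `O=C(Nc1c(C(O)(C(F)(F)F)C(F)(F)F)ccc2ccccc12)c1cccc(Cl)c1` carries the change (3-chlorophenyl in place of cyclobutyl on a carbonyl carbon). Among the compounds with values here, the only measured step, a number 3 percentage points lower from compound 1 to compound 2 (within the scatter), swaps one non-aromatic ring for another and says little about an aromatic entrant, so no shift beyond the scatter is foreseen, with wide uncertainty. Compound 3 is therefore expected near 90% (55% to 105%), an expected step of a number 7 percentage points lower from compound 2 to compound 3 (within the scatter).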

Compound 3, largest response reached (reported as efficacy), in percent of the reference or control that the assay uses: 84%
For compound 3 the middle estimate is 6 percentage points above the measured one; low and high end bracket the measured number.
By their numbers in this assay, from the lowest: compound 3; then compounds 2 and 1 (each within the scatter of the next).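

With 3-chlorophenyl on the carbonyl carbon, this position shows its first shift beyond the scatter in this assay, with a number a number 13 percentage points lower from compound 2 to compound 3 (beyond the scatter) and likewise a number 16 percentage points lower from compound 1 to compound 3 (beyond the scatter). Cyclopropyl and cyclobutyl did not separate, so the acyl group can alter the maximal response, though only modestly here. Compound 3 keeps a substantial response with the aromatic ring in place.

Open, as far as these compounds go, is whether the aromatic ring or the chlorine carries the shift, which unsubstituted phenyl would address, and how an aminomethyl group or a longer alkyl chain would read here. Nothing available speaks to what lies behind the shift.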